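The source may hold more compounds than are shown below. What is called first, only, known or untested is meant among the compounds shown, and "the series" means these compounds.

Measured in an assay on isolated protein for inhibition of interferon-induced, double-stranded RNA-activated protein kinase (Homo sapiens), read by luminescence, with a stated time of 10 min; a lower number here means a stronger inhibitor, a higher number a weaker inhibitor:

Compound 1 `Nc1nc(Nc2ccc(S(N)(=O)=O)cc2)nn1C(=O)Nc1c(F)cccc1F` gives 8000 nM.
Compound 2 `O=C1Cc2ccc(Oc3ccc4c(c3)NC(=O)C4)cc2N1` gives 14000 nM.
Compound 3 `Cc1[nH]c2ccccc2c1-c1ccnc(NCCO)n1` gives 11000 nM.

All three compounds are weak inhibitors in this assay, and the three numbers lie within the usual scatter of one another: compound 3 stands among them with no gap to either neighbour that would count as a real difference, neither to compound 2 nor to compound 1. The step to the unmeasured compound 4 `OCCNc1nccc(-c2c[nH]c3ccccc23)n1` changes compound 3 in one place: hydrogen in place of methyl on an aromatic carbon. Going by the values given here, no step between measured compounds is available to show what such a change does, and the three measured compounds share no such pair. With only this to go on, the expected step in this assay is small, in either direction, and most likely nothing beyond the scatter. Compound 4 is therefore expected to remain a weak inhibitor, with an estimated value of 9000 nM, in a range from 3000 nM to 30000 nM, which corresponds to an expected step of a 1.2-fold lower number from compound 3 to compound 4 (0.09 log units; within the scatter).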

Compound 4, half-maximal inhibitory concentration: 11000 nM
Compound 4: the middle estimate sits 1.2-fold (0.09 log units) below what was measured; the measured number falls inside the stated range.
By their numbers in this assay, from the lowest: compounds 1, 3, 4 and 2 (each within the scatter of the next).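

In this assay, hydrogen in place of methyl on the aromatic carbon next to the ring nitrogen gives no change at the digits printed from compound 3 to compound 4 (within the scatter). Going by these compounds alone, this is the first single change that can be read in this set, and it shows that the methyl at this place is not needed for the weak inhibition seen with compound 3: the loss of this one heavy atom leaves the number where it stood. Nothing measured here bears on why the number holds.

The compounds shown leave open whether a larger group at this place, such as ethyl, chloro or phenyl, would move the number beyond the scatter. Going by these compounds, it also remains open what an amine or a carboxylic acid on the same carbon would do.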